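A Fluoro for Chloro Swap at Short Half-Life

This account rests on a few compounds, and the source may have more. Where it says the series, first, only, none or still open, it means among the compounds named here.

In an ADME assay on microsomes from liver (Rattus norvegicus) for metabolic stability, read by LC-MS, using NADPH, at 37 degrees C (a higher number here means that the compound lasts longer, a lower number that the compound disappears faster), compound 1 `Cc1cc(C)c(-c2nc(CN3CCC(C(=O)NCCCN4C[C@H](C)C[C@H](C)C4)CC3)c(C)o2)c(C)c1` gives > 0.5 h, which is a limit and not a number. Compound 2 `Cc1oc(-c2c(Br)cccc2Br)nc1CN1CCC(C(=O)NCCCN2C[C@H](C)C[C@H](C)C2)CC1` gives 0.035 h and compound 3 `COc1cccc(Cl)c1-c1nc(CN2CCC(C(=O)NCCCN3C[C@H](C)C[C@H](C)C3)CC2)c(C)o1` gives 0.055 h. These two values lie within the scatter of each other, as a 1.6-fold higher number from compound 2 to compound 3 (0.20 log units; within the scatter) shows. Both sit well under compound 1, with an at least 14-fold lower number from compound 1 to compound 2 (1.15 log units; beyond the scatter) and an at least 9.0-fold lower number from compound 1 to compound 3 (0.95 log units; beyond the scatter). Compound 4 `COc1cccc(F)c1-c1nc(CN2CCC(C(=O)NCCCN3C[C@H](C)C[C@H](C)C3)CC2)c(C)o1` carries fluoro in place of chloro on an aromatic carbon. For the measured compounds named here, no measured step makes this swap alone. The nearest is a 1.6-fold higher number from compound 2 to compound 3 (0.20 log units; within the scatter), also a change of substituents on this ring, and it stayed within the scatter. The expected result in this assay is therefore a 1.1-fold higher number from compound 3 to compound 4 (0.04 log units; within the scatter), with no step beyond the scatter. For compound 4 the estimate is 0.06 h, within a range of 0.03 h to 0.14 h.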

Compound 4, half-life: 0.143 h
For compound 4 the middle estimate is 2.4-fold (0.38 log units) below the measured one; measured number above the stated range.
By their numbers in this assay, from the lowest: compounds 2 and 3 (each within the scatter of the next); then compound 4. At a limit, above all of these: compound 1.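

In this assay, swapping chloro for fluoro on this ring, ortho to a large group and meta to a methoxy group, gives a 2.6-fold higher number from compound 3 to compound 4 (0.41 log units; beyond the scatter), so one atom at this place moves the number beyond the scatter, unlike the earlier change on this ring, a 1.6-fold higher number from compound 2 to compound 3 (0.20 log units; within the scatter). The 2-fluoro-6-methoxyphenyl group also clears the 2,6-dibromophenyl group, with a 4.1-fold higher number from compound 2 to compound 4 (0.61 log units; beyond the scatter). The 2,4,6-trimethylphenyl group of compound 1 stays ahead, with an at least 3.4-fold lower number from compound 1 to compound 4 (0.54 log units; beyond the scatter), a step read against a limit and not a number: the limit of > 0.5 h in this assay, at which 1 of the 4 values shown sits.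

Going by these compounds, whether hydrogen or a nitrile in place of the fluoro would carry the number further stays open. So does whether fluoro gives the same step with methyl in place of the methoxy group.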